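A few compounds are considered here, and "the series" means these few. Any claim that something is new, unique, unknown or untested is made for them only; others in the source may bear on it.

For the measured compounds named here, compound 2, with the structure `CC(=O)N1CCC(NC(=O)N2CCC(c3nc(-c4ccc5ccccc5n4)no3)CC2)CC1`, is the weakest inhibitor among the three compounds measured so far: in a functional assay on Shh Light II cells (Mus musculus) for inhibition, read by a luciferase reporter (a higher number here means a weaker inhibitor, a lower number a stronger inhibitor), compound 2 gives 500 nM. Compound 1, built as `O=C(NC1CCCCC1)N1CCN(c2nc(-c3ccc4ccccc4n3)no2)CC1`, gives 53 nM in this assay, and compound 3, built as `Cn1c(-c2noc(N3CCN(C(=O)NC4CCCCC4)CC3)n2)nc2ccccc21`, gives 5 nM. Going by the values given here, the one single-point step available, an 11-fold lower number from compound 1 to compound 3 (1.03 log units; beyond the scatter), concerns the aromatic group on the far side of the shared core and leaves the urea end untouched.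

Compound 4, with the structure `O=C(N1CCC(c2nc(-c3ccc4ccccc4n3)no2)CC1)N1CCCc2ccccc21`, differs from compound 2 at that urea end: 1,2,3,4-tetrahydroquinolin-1-yl in place of (1-acetylpiperidin-4-yl)amino on a carbonyl carbon. A ring with a hydrogen-bond donor and an acceptor gives way to a fused bicyclic group without either.

Among the compounds with values here, no measured step touches the urea substituent, so the known step from compound 1 to compound 3 gives no direct guide here. Compound 1 and compound 2 differ in two places at once, so their values show only that a smaller urea partner went together with a lower number. On that slim basis a moderate move downward is expected, with wide uncertainty: the estimated step is a 3.3-fold lower number from compound 2 to compound 4 (0.52 log units; beyond the scatter), and compound 4 is expected to give about 150 nM in this assay, within a range from 30 nM to 800 nM.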

Compound 4, half-maximal inhibitory concentration: 2300 nM
Estimate against measurement, compound 4: 15-fold (1.19 log units) below; measured number outside the range, above it.
By their numbers in this assay, from the lowest: compound 3; then compound 1; then compound 2; then compound 4.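

For the compounds shown here, until this result, no measured pair isolated the group on the urea carbonyl carbon. In this assay, 1,2,3,4-tetrahydroquinolin-1-yl in place of (1-acetylpiperidin-4-yl)amino brings a 4.6-fold higher number from compound 2 to compound 4 (0.66 log units; beyond the scatter), a modest step but beyond the scatter, so this position does respond to what it carries, even with 10 heavy atoms in both the leaving and the entering group. The entering group adds an aromatic ring and has no hydrogen-bond donor or acceptor, but no measured evidence is available to explain the step or say which of these differences matters.

An anilino group on the same carbonyl carbon would keep the amide hydrogen alongside an aromatic ring, and a piperidin-4-ylamino group without the acetyl would test that part of the leaving group, but the compounds shown leave open how either would read. Also open, from the compounds shown here alone, is whether the same exchange would give a step of similar size in compounds carrying 1-methyl-1H-benzimidazol-2-yl in place of quinolin-2-yl.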